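The compounds below may be only part of what the source reports. "The series", "measured", "known", "first", "only" and "open" are said of these compounds alone.

Measured compounds:
compound 1, `C[C@H]1CC[C@@H]2[C@@H](OC(=O)[C@]23CC(c2ccccc2)=NO3)[C@]2(C)C(=O)C=C[C@@]12O`: 1.41
compound 2, `C[C@H]1CC[C@@H]2[C@@H](OC(=O)[C@]23CC(c2ccccc2[N+](=O)[O-])=NO3)[C@]2(C)C(=O)C=C[C@@]12O`: 1.37
compound 3, `C[C@H]1CC[C@@H]2[C@@H](OC(=O)[C@]23CC(c2ccc([N+](=O)[O-])cc2)=NO3)[C@]2(C)C(=O)C=C[C@@]12O`: 1.37

In a physicochemical assay for lipophilicity (on this read-out lower numbers stand for lower lipophilicity and higher numbers for higher lipophilicity), compound 1 stands at 1.41, and compound 2 at 1.37 as well as compound 3 at 1.37 lie within the usual scatter of it, so the three numbers are not told apart.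

Compound 4 is `C[C@H]1CC[C@@H]2[C@@H](OC(=O)[C@]23CC(c2cccc([N+](=O)[O-])c2)=NO3)[C@]2(C)C(=O)C=C[C@@]12O`. From compound 1 it differs in one place: nitro in place of hydrogen on an aromatic carbon. Two measured steps carry the same change, a number 0.04 log units lower from compound 1 to compound 2 (within the scatter) and a number 0.04 log units lower from compound 1 to compound 3 (within the scatter); the two nitrophenyl compounds also sit alike, no change at the digits printed from compound 2 to compound 3 (within the scatter). No step beyond the scatter in this assay is therefore expected; only a small drop is estimated, a number 0.04 log units lower from compound 1 to compound 4 (within the scatter). For compound 4 the estimate is 1.37, with a range from 1.22 to 1.52.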

Compound 4, partition coefficient: 1.37
Estimate against measurement, compound 4: no gap at the digits printed, within the range that was stated.
By their numbers in this assay, from the lowest: compounds 2, 3, 4 and 1 (each within the scatter of the next).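

In this assay the 3-nitrophenyl compound also stays close to the unsubstituted phenyl, with a number 0.04 log units lower from compound 1 to compound 4 (within the scatter) as the step for nitro in place of hydrogen. Among the nitrophenyl compounds, the read-out gives no change at the digits printed from compound 3 to compound 4 (within the scatter) and no change at the digits printed from compound 2 to compound 4 (within the scatter) so all three nitro placements in this series now sit within the scatter of one another and of compound 1. Nothing at hand bears on why these numbers sit together.

As far as these compounds go, whether an amine, a carboxylic acid or a longer chain on the phenyl ring would give a step beyond the scatter in this assay stays open. So does the effect of any change on the shared core.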